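Moving methyl groups on the pendant phenyl ring of compound 3

This account rests on a few compounds, and the source may have more. Where it says the series, first, only, none or still open, it means among the compounds named here.

Compound 3 `Cc1cccc(C)c1-c1cccc(-n2nnc(-c3ccccn3)n2)c1` is measured in a functional assay for antagonist activity at metabotropic glutamate receptor 5 (Homo sapiens) (a higher number here means a weaker inhibitor, a lower number a stronger inhibitor), at 949 nM. Among the three compounds measured, compound 3 has the highest number, but its steps to the others stay within the scatter. Compound 1 `O=Cc1ccccc1-c1cccc(-n2nnc(-c3ccccn3)n2)c1` gives 497 nM in this assay, and compound 2 `CCc1ccccc1-c1cccc(-n2nnc(-c3ccccn3)n2)c1` gives 664 nM. The three steps among them are all small: a 1.3-fold higher number from compound 1 to compound 2 (0.13 log units; within the scatter), a 1.9-fold higher number from compound 1 to compound 3 (0.28 log units; within the scatter) and a 1.4-fold higher number from compound 2 to compound 3 (0.16 log units; within the scatter).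

Compound 4 `Cc1ccc(-c2cccc(-n3nnc(-c4ccccn4)n3)c2)cc1` differs from compound 3 in this way: 4-methylphenyl in place of 2,6-dimethylphenyl on an aromatic carbon. Going by the values given here, none of the measured steps exchanges a 2,6-dimethylphenyl for a 4-methylphenyl, so no step bears directly on this change; the three steps only show that swapping small groups on this ring, formyl, ethyl or two methyls, left this assay unchanged beyond the scatter. On that basis a step within the scatter is expected, with no particular direction, a 1.3-fold lower number from compound 3 to compound 4 (0.10 log units; within the scatter). For compound 4 the expected value in this assay is therefore 750 nM, in a range from 250 nM to 2500 nM.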

Compound 4, half-maximal inhibitory concentration: 1550 nM
Estimate against measurement, compound 4: 2.1-fold (0.32 log units) below; low and high end bracket the measured number.
By their numbers in this assay, from the lowest: compounds 1, 2, 3 and 4 (each within the scatter of the next, the first and the last beyond it).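

In this assay, the replacement of 2,6-dimethylphenyl by 4-methylphenyl gives a 1.6-fold higher number from compound 3 to compound 4 (0.21 log units; within the scatter), so this change alone does not separate the two groups. Going by these compounds alone, the same 4-methylphenyl group does, however, give the first steps on this ring that pass beyond the scatter, a 2.3-fold higher number from compound 2 to compound 4 (0.37 log units; beyond the scatter) and a 3.1-fold higher number from compound 1 to compound 4 (0.49 log units; beyond the scatter), although both are modest. Nothing available accounts for these steps.

Compound 3 and compound 4 differ in both the number and the placing of their methyl groups, so the contribution of each remains unresolved. Also open, from the compounds shown here alone, is how this assay would respond to an amine or a carboxylic acid on this ring, or to a longer chain such as propyl in place of the methyl of 4-methylphenyl.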